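The source may hold more compounds than are shown below. What is called first, only, known or untested is meant among the compounds shown, and "the series" means these compounds.

Compound 1: `CC1(C)[C@H]2CC[C@]1(C)N(Cc1cn(-c3cccc(F)c3)nn1)C(=O)C2` — 530 nM
Compound 2: `CC1(C)[C@H]2CC[C@]1(C)N(Cc1cn(-c3cccc(Cl)c3)nn1)C(=O)C2` — 510 nM
Compound 3: `CC1(C)[C@H]2CC[C@]1(C)N(Cc1cn(-c3ccccc3)nn1)C(=O)C2` — 240 nM

These three share one core and differ only in a single group on the aromatic ring. In a functional assay on SGC-7901 cells (Homo sapiens) for inhibition, read by MTT assay, with a stated time of 24 h (a higher number here means a weaker inhibitor, a lower number a stronger inhibitor), compound 1 gives the highest number of the three. Compound 2 sits essentially at the same level, as a 1.0-fold lower number from compound 1 to compound 2 (0.02 log units; within the scatter) shows. Compound 3 lies lower: a 2.2-fold lower number from compound 1 to compound 3 (0.34 log units; beyond the scatter) and a 2.1-fold lower number from compound 2 to compound 3 (0.33 log units; beyond the scatter) are both modest steps that go beyond the scatter.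

Compound 4, `CC1(C)[C@H]2CC[C@]1(C)N(Cc1cn(-c3cccc(Br)c3)nn1)C(=O)C2`, has not been measured. It differs from compound 1 by bromo in place of fluoro on an aromatic carbon. Going by the values given here, the one measured step that bears on this kind of swap, one halogen exchanged for another, is a 1.0-fold lower number from compound 1 to compound 2 (0.02 log units; within the scatter), which changed nothing beyond the scatter. The two steps that removed the halogen altogether, a 2.2-fold lower number from compound 1 to compound 3 (0.34 log units; beyond the scatter) and a 2.1-fold lower number from compound 2 to compound 3 (0.33 log units; beyond the scatter), went downward, but they describe a different change. The expectation for compound 4 is therefore no step beyond the scatter, with a 1.0-fold lower number from compound 1 to compound 4 (0.01 log units; within the scatter) close to nothing. Compound 4 is estimated to give 520 nM in this assay, within a range from 260 nM to 1040 nM.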

Compound 4, half-maximal inhibitory concentration: 120 nM
Compound 4: middle estimate off by 4.3-fold (0.64 log units), on the high side; the whole stated range lies above it.
By their numbers in this assay, from the lowest: compounds 4 and 3 (each within the scatter of the next); then compounds 2 and 1 (each within the scatter of the next).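

At this position on the aromatic ring, the identity of the halogen can matter, which the earlier swap did not reveal: in this assay, a 1.0-fold lower number from compound 1 to compound 2 (0.02 log units; within the scatter), whereas bromo gives a 4.4-fold lower number from compound 1 to compound 4 (0.65 log units; beyond the scatter) and a 4.3-fold lower number from compound 2 to compound 4 (0.63 log units; beyond the scatter). Compound 4 also breaks the earlier pattern in which the halogen-bearing compounds gave higher numbers than the unsubstituted phenyl compound: a 2.0-fold lower number from compound 3 to compound 4 (0.30 log units; within the scatter), so bromo and hydrogen cannot be told apart here, while fluoro and chloro stand apart from both. Nothing available explains why bromo departs from the other two halogens.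

The compounds shown carry only hydrogen, fluoro, chloro or bromo at this one place on the ring. On these data alone, how iodo, methyl or methoxy would read here stays open, as does whether bromo would give a similar number elsewhere on the ring.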